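Thiosemicarbazones of a thiophene aldehyde: changing the aryl cap

This account rests on a few compounds, and the source may have more. Where it says the series, first, only, none or still open, it means among the compounds named here.

Measured so far:
compound 1, `S=C(N/N=C/c1cccs1)Nc1cccc2ccccc12`, 12700 nM;
compound 2, `CCc1ccc(NC(=S)N/N=C/c2cccs2)cc1`, > 100000 nM;
compound 3, `S=C(N/N=C/c1cccs1)Nc1cccnc1`, 26000 nM.

These three share a thiosemicarbazone core and differ in the aromatic group on the thiourea nitrogen. In a functional assay on U-251 cells (Homo sapiens) for inhibition, read by sulforhodamine B assay, with a stated time of 48 h (on this read-out lower numbers stand for stronger inhibition of growth and higher numbers for weaker inhibition of growth), compound 1 gives 12700 nM and compound 3 gives 26000 nM. For compound 2 this assay reports only a limit, > 100000 nM, so its number is not known; it sits at the limit of > 100000 nM in this assay, at which 1 of the 3 values shown sits.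

The next compound, compound 4, `COc1ccc(NC(=S)N/N=C/c2cccs2)cc1`, is built from compound 2 by one change: methoxy in place of ethyl on an aromatic carbon. Going by the values given here, both groups are small and uncharged, and nothing among the measured compounds speaks to what a methoxy does on this ring. Among the compounds with values here, since compound 2 itself is known only as a limit, the account can expect no step from it beyond the scatter in this assay; the step of an at least 1.2-fold lower number from compound 2 to compound 4 (0.09 log units; that floor lies within the scatter) is what the estimate means, with a real chance that compound 4 also returns only a limit. Compound 4 is therefore expected to give about 80000 nM, within 25000 nM to 250000 nM.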

Compound 4, concentration for 50% growth inhibition: > 100000 nM
Compound 4: no number, only a limit (the forecaster's own chance of this, stated with the estimate: 50%); middle value at least 1.2-fold (0.09 log units) from the limit.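

In this assay, going by these compounds alone, compound 4 returns only a limit, as compound 2 does, so no step between the two can be read: the limit of > 100000 nM in this assay, at which 2 of the 4 values shown sit. The compounds shown leave open whether methoxy and ethyl on this ring differ at all in their inhibition of growth.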